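The compounds below may be only part of what the source reports. "The series", "measured", "known", "first", "only" and "open" are said of these compounds alone.

Values in a functional assay on HCT-116 cells (Homo sapiens) for cytotoxicity, read by sulforhodamine B assay, with a stated time of 24 h; on this read-out higher numbers stand for weaker inhibition and lower numbers for stronger inhibition:
- compound 1 `N#CCC(=O)N/N=C1\C(=O)Nc2ccc(S(=O)(=O)N3CCOCC3)cc21`: 10300 nM
- compound 2 `COc1ccc(-c2c(C#N)c(N)n(/N=C3\C(=O)Nc4ccc(S(=O)(=O)N5CCOCC5)cc43)c(=O)c2C#N)cc1`: 18100 nM
- compound 3 `N/N=C1\C(=O)Nc2ccc(S(=O)(=O)N3CCOCC3)cc21`: 36300 nM

Compound 3 lies within the scatter of compound 2, while its number is clearly higher than that of compound 1. Compound 4 `O=C1Nc2ccc(S(=O)(=O)N3CCOCC3)cc2/C1=N/NS(=O)(=O)c1ccccc1` is unmeasured and differs from compound 3 as follows: phenylsulfonyl in place of hydrogen on an amine nitrogen. In words, it has phenylsulfonyl in place of hydrogen on an amine nitrogen.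

Going by the values given here, one measured step bears on this change: a 3.5-fold higher number from compound 1 to compound 3 (0.55 log units; beyond the scatter), a modest step that removes (cyanomethyl)carbonyl from the same amine nitrogen. Read backwards, it suggests that a group entering at this place may lower the number. Among the compounds with values here, the series holds no measured phenylsulfonyl example, so this is only an analogy. The values of compound 2 and compound 3 also sit within the scatter of each other, so the upper end of the range stays close to compound 3.

The expected change is a 2.4-fold lower number from compound 3 to compound 4 (0.38 log units; beyond the scatter), a modest step towards a lower number. For compound 4 the estimated value is 15000 nM, with an expected range of 5000 nM to 40000 nM.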

Compound 4, half-maximal inhibitory concentration: 13300 nM
The estimate for compound 4 lay 1.1-fold (0.05 log units) above the measured number, and the stated range covers the measured number.
By their numbers in this assay, from the lowest: compounds 1, 4, 2 and 3 (each within the scatter of the next, the first and the last beyond it).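

In this assay, the amine nitrogen of compound 3 now has a second substituent that lowers the number (a 2.7-fold lower number from compound 3 to compound 4 (0.44 log units; beyond the scatter)), so this effect is no longer tied to the (cyanomethyl)carbonyl group of compound 1. Exchanging that group for phenylsulfonyl gives a 1.3-fold higher number from compound 1 to compound 4 (0.11 log units; within the scatter) and so does not separate the two, which means that this nitrogen tolerates both a sulfonyl and a carbonyl link without a readable difference. No available measurement accounts for either step.

Still open, going by these compounds, is whether a smaller group on this nitrogen, such as acetyl or methylsulfonyl, would match these two substituents or fall back towards compound 3. Also open, on these data alone, is whether a chlorine or a methoxy group on the phenyl ring of compound 4 would move the number at all.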